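Inverting one ring stereocentre: the solubility of compound 4

The source may hold more compounds than are shown below. What is called first, only, known or untested is meant among the compounds shown, and "the series" means these compounds.

Measured in a physicochemical assay for solubility, at pH 7.4; a lower number here means a less soluble compound, a higher number a more soluble compound:
- Compound 1 `C[C@@H]1[C@@H](N(C)C)CN1c1c(F)cc2c(=O)c(C(=O)O)cn(C3CC3)c2c1F`: 97.1 ug/mL
- Compound 2 `C[C@H]1N(c2c(F)cc3c(=O)c(C(=O)O)cn(C4CC4)c3c2F)C[C@]1(C)N`: 3.3 ug/mL
- Compound 3 `C[C@H]1[C@@H](N)CN1c1c(F)cc2c(=O)c(C(=O)O)cn(C3CC3)c2c1F`: 23.6 ug/mL

Compound 3, at 23.6 ug/mL, holds the middle place among the three values, with compound 1 above it and compound 2 below it. Compound 4 `C[C@H]1[C@H](N)CN1c1c(F)cc2c(=O)c(C(=O)O)cn(C3CC3)c2c1F` is the next to be tested, and its relation to compound 3 is this: the two compounds have the same atoms and bonds and differ only in configuration as drawn: 1 of 2 stereo elements differ; a stereocentre at a saturated ring carbon is drawn S in compound 3 and R in compound 4.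

Among the compounds with values here, none of the measured steps isolates a change of configuration. Each one also alters the size of the group on the aromatic carbon. They bear on the question only indirectly, by showing how far this assay moves among these close relatives: a 4.1-fold lower number from compound 1 to compound 3 (0.61 log units; beyond the scatter), a 7.2-fold higher number from compound 2 to compound 3 (0.85 log units; beyond the scatter) and a 29-fold lower number from compound 1 to compound 2 (1.47 log units; beyond the scatter). They give no direction for an inversion, so a modest step of either sign remains possible, and the estimate stays centred near compound 3. The expected change is a 1.1-fold higher number from compound 3 to compound 4 (0.03 log units; within the scatter). For compound 4 the estimated value is 25 ug/mL, with an expected range from 7 ug/mL to 90 ug/mL.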

Compound 4, solubility: 23.2 ug/mL
Compound 4: the middle estimate sits 1.1-fold (0.03 log units) above what was measured, within the range that was stated.
By their numbers in this assay, from the lowest: compound 2; then compounds 4 and 3 (each within the scatter of the next); then compound 1.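

In this assay, inverting the saturated ring carbon from S to R gives a 1.0-fold lower number from compound 3 to compound 4 (0.01 log units; within the scatter), so at this stereocentre, with the other stereo element held as drawn, the two configurations cannot be told apart. This step can be read as one of configuration alone for a single reason: the fact that compounds 3 and 4 differ only in the configuration as drawn. Compound 4 also stands about as far from the other compounds as compound 3 does, with a 7.0-fold higher number from compound 2 to compound 4 (0.85 log units; beyond the scatter) and a 4.2-fold lower number from compound 1 to compound 4 (0.62 log units; beyond the scatter), so the steps beyond the scatter in this set all go with a change in the size of the group on the aromatic carbon, not with this inversion.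

The compounds shown leave open whether inverting the other stereo element, or both together, would also stay within the scatter. They also leave open how a hydroxyl group or a longer chain on the four-membered ring would behave in this assay.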